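One more chloro group at a shared limit

The compounds below may be only part of what the source reports. "The series", "measured", "known", "first", "only" and "open" are said of these compounds alone.

Compound 1 `O=S(=O)(Nc1ccc(Cl)cc1Cl)c1ccc(-c2cnc(C3CC3)o2)cc1`: > 100000 nM (a limit)
Compound 2 `O=S(=O)(Nc1ccc(F)c(Cl)c1)c1ccc(-c2cnc(C3CC3)o2)cc1`: > 100000 nM (a limit)
Compound 3 `O=S(=O)(Nc1cccc(Cl)c1)c1ccc(-c2cnc(C3CC3)o2)cc1`: > 100000 nM (a limit)

These results all come from a functional assay on cells (leukaemia cell line, Homo sapiens) for inhibition, read by sulforhodamine B assay, with a stated time of 48 h (a lower number here means that less compound is tolerated, a higher number that more compound is tolerated), and none of them is an exact number. Compound 3 has only a limit of the assay, > 100000 nM.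

Compound 4 `O=S(=O)(Nc1cc(Cl)ccc1Cl)c1ccc(-c2cnc(C3CC3)o2)cc1` differs from compound 3 by one change: chloro in place of hydrogen on an aromatic carbon. This places chloro in place of hydrogen on an aromatic carbon, turning 3-chlorophenyl into 2,5-dichlorophenyl.

Among the compounds with values here, three measured steps bear on this change: a step that the two limits leave unreadable from compound 1 to compound 3, a step that the two limits leave unreadable from compound 1 to compound 2 and a step that the two limits leave unreadable from compound 2 to compound 3. All of them end at one mark, (the limit of > 100000 nM in this assay, at which 3 of the 3 values shown sit), so none has a readable size. Compound 1, which also carries a second chloro group on that ring, gives > 100000 nM, again a limit.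

No step beyond the usual scatter is therefore expected in this assay, in either direction, and the estimated size is a number no higher from compound 3 to compound 4 (the limit leaves the size open). A report of a limit is the most likely outcome. For compound 4 the estimated value is 100000 nM, with an expected range from 50000 nM to 200000 nM.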

Compound 4, concentration lethal to 50% of the cells: > 100000 nM
Compound 4 ended at the assay's limit (the forecaster's own chance of this, stated with the estimate: 90%); the middle value sits exactly at the limit.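

No step can be read between compound 4 and compounds 1, 2 or 3 in this assay, because all four compounds end at the same mark: the limit of > 100000 nM in this assay, at which 4 of the 4 values shown sit.

The compounds shown leave open whether changing the chloro and fluoro groups on this phenyl ring alters the lethal concentration at all.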